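The source may hold more compounds than are shown below. What is called first, only, known or untested is meant among the compounds shown, and "the series" means these compounds.

Compound 1 `NC1CCC(CN2CCN(c3cc(=O)c4cc(C(F)(F)F)cc([N+](=O)[O-])c4s3)CC2)CC1`: 83.6%
Compound 2 `Nc1cc(C(F)(F)F)cc2c(=O)cc(N3CCN(CC4CCCCC4)CC3)sc12`: 0.9%

Both compounds were measured in an ADME assay on cells (Hepatocyte, Homo sapiens) for metabolic stability, with a stated time of 30 min; on this read-out lower numbers stand for a less stable compound and higher numbers for a more stable compound. Compound 2 stands lowest of the two numbers, and compound 1 lies higher by a gap beyond the scatter. Compound 3 `Nc1cc(C(F)(F)F)cc2c(=O)cc(N3CCN(CC4CCC(O)CC4)CC3)sc12` has not yet been measured; it differs from compound 2 by hydroxy in place of hydrogen on a saturated ring carbon. For the measured compounds named here, no step between two measured compounds matches this change, so the size of the step in this assay rests on expectation alone: a moderate rise beyond the scatter is expected. Compound 3 is accordingly estimated at 15%, within a range from 1% to 45%. This amounts to an expected step of a number 14.1 percentage points higher from compound 2 to compound 3 (beyond the scatter).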

Compound 3, percent of the compound remaining: 72.9%
Estimate against measurement, compound 3: 57.9 percentage points below; the whole stated range lies below it.
By their numbers in this assay, from the lowest: compound 2; then compound 3; then compound 1.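

In this assay, for the compounds shown here, the change from cyclohexylmethyl to (4-hydroxycyclohexyl)methyl gives a number 72 percentage points higher from compound 2 to compound 3 (beyond the scatter) and is the first comparison here of compounds that differ in one place. It shows that on this saturated ring carbon, three ring bonds from the ring atom that bears a large group, a single hydroxy in place of hydrogen is enough for a large step. No measurement shown here accounts for the size of this step. The compounds shown leave open whether the rise is particular to hydroxy or would also come with a methoxy, an amine or a carboxylic acid on the same ring carbon.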